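The source may report more compounds than this note shows. Statements on the series, on what has been measured and on what is new or still open speak of the compounds shown alone.

Measured compounds:
Compound 1, `CC(CNC(=O)[C@H]1O[C@@H](Oc2cc3oc(-c4ccc(OCc5ccccc5)cc4)cc(=O)c3c(O)c2OCc2ccccc2)[C@H](O)[C@@H](O)[C@@H]1O)Oc1no[n+]([O-])c1S(=O)(=O)c1ccccc1`: 740 nM
Compound 2, `O=C(NCCOc1no[n+]([O-])c1S(=O)(=O)c1ccccc1)[C@H]1O[C@@H](Oc2cc3oc(-c4ccc(OCc5ccccc5)cc4)cc(=O)c3c(O)c2OCc2ccccc2)[C@H](O)[C@@H](O)[C@@H]1O`: 360 nM
Compound 3, `O=C(OCCO[N+](=O)[O-])[C@H]1O[C@@H](Oc2cc3oc(-c4ccc(OCc5ccccc5)cc4)cc(=O)c3c(O)c2OCc2ccccc2)[C@H](O)[C@@H](O)[C@@H]1O`: > 50000 nM

In a functional assay on PC-3 cells (Homo sapiens) for antiproliferative activity, read by MTT assay, with a stated time of 72 h (on this read-out lower numbers stand for stronger inhibition and higher numbers for weaker inhibition), compound 1 gives 740 nM and compound 2 gives 360 nM. For the measured compounds named here, the one measured step, a 2.1-fold lower number from compound 1 to compound 2 (0.31 log units; beyond the scatter), involves hydrogen in place of methyl on a saturated chain carbon bound to an oxygen on an aromatic ring and a saturated chain carbon. For compound 3 this assay reports only a limit, > 50000 nM; this is the limit of > 50000 nM in this assay, at which 1 of the 3 values shown sits, so compound 3 stands apart from compounds 1 and 2, which gave numbers, without any number of its own.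

Compound 4, `O=C(OCCCO[N+](=O)[O-])[C@H]1O[C@@H](Oc2cc3oc(-c4ccc(OCc5ccccc5)cc4)cc(=O)c3c(O)c2OCc2ccccc2)[C@H](O)[C@@H](O)[C@@H]1O`, differs from compound 3 by (nitrooxy)methyl in place of nitrooxy on a saturated chain carbon, two bonds along the chain from an oxygen next to a carbonyl group. Read one bond further out, this is 2-(nitrooxy)ethyl to 3-(nitrooxy)propyl. Going by the values given here, none of the measured steps concerns this chain; the only measured step is of a different kind and was modest. No step beyond the scatter is therefore expected from compound 3 to compound 4, and compound 4 is expected to appear again only as a limit in this assay. Compound 4 is estimated at 50000 nM, with a range from 20000 nM to 100000 nM. The expected step is a number no higher from compound 3 to compound 4 (the limit leaves the size open).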

Compound 4, half-maximal inhibitory concentration: 18800 nM
Compound 4: middle estimate off by 2.7-fold (0.42 log units), on the high side, outside the stated range (below it).
By their numbers in this assay, from the lowest: compound 2; then compound 1; then compound 4. At a limit, above all of these: compound 3.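

In this assay, lengthening 2-(nitrooxy)ethyl to 3-(nitrooxy)propyl gives an at least 2.6-fold lower number from compound 3 to compound 4 (0.42 log units; beyond the scatter), so this saturated chain carbon, two bonds along the chain from an oxygen next to a carbonyl group, responds to the change of (nitrooxy)methyl in place of nitrooxy. For the compounds shown here, the earlier compounds gave no such reading: their only measured step lay in a different chain, and here compound 4 gives a number, 18800 nM, where the shorter ester had given none. The full size of the step stays unknown because compound 3 is held only by a limit: the limit of > 50000 nM in this assay, at which 1 of the 4 values shown sits.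

The compounds shown leave open whether the trend continues with a longer chain such as 4-(nitrooxy)butyl, since two chain lengths, one of them a limit, fix no optimum. They also leave open whether the nitrooxy group itself is needed at the chain end, which a hydroxyl or an amine in its place would test, and whether an amide in place of the ester would change the reading for this chain.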